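The compounds below may be only part of what the source reports. "The series", "measured", "known", "first", "only" and "open" are said of these compounds alone.

In a functional assay on A549 cells (Homo sapiens) for cytotoxicity, read by MTT assay, with a stated time of 72 h (on this read-out higher numbers stand for weaker inhibition and lower numbers for stronger inhibition), compound 1 `COc1ccc(NC(=O)CN2CCN(c3nnc(Cc4ccncc4)c4ccccc34)CC2)cc1OC` gives 26500 nM, the higher of the two numbers available. Compound 3 `O=C(CN1CCN(c2nnc(Cc3ccccc3)c3ccccc23)CC1)Nc1ccc(F)c(F)c1` gives 10100 nM, a lower number that marks stronger inhibition, while compound 2 `COc1ccc(NC(=O)CN2CCN(c3nnc(Cc4ccccc4)c4ccccc34)CC2)cc1OC` is reported only as "not active" (no number reported). Compound 4 `O=C(CN1CCN(c2nnc(Cc3ccncc3)c3ccccc23)CC1)Nc1ccc(F)c(Cl)c1` differs from compound 1 in one place: 3-chloro-4-fluorophenyl in place of 3,4-dimethoxyphenyl on an amide-type nitrogen. Among the measured compounds shown here, no measured pair shows this single change on its own, so the evidence is indirect. The halogen-bearing compound 3, at 10100 nM, suggests a moderate move toward stronger inhibition. The expected change is a 2.0-fold lower number from compound 1 to compound 4 (0.31 log units; beyond the scatter). Compound 4 is estimated at 13000 nM, with an expected range of 5000 nM to 32000 nM.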

Compound 4, half-maximal inhibitory concentration: 12300 nM
Estimate against measurement, compound 4: 1.1-fold (0.02 log units) above; measured number inside the range.
By their numbers in this assay, from the lowest: compounds 3 and 4 (each within the scatter of the next); then compound 1.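

In this assay, 3-chloro-4-fluorophenyl in place of 3,4-dimethoxyphenyl on the amide-type nitrogen gives a modest move toward stronger inhibition (a 2.2-fold lower number from compound 1 to compound 4 (0.33 log units; beyond the scatter)). Among the compounds shown here, this is the first pair that differs in this one place alone, so the effect of this change can now be read directly, with the rest of the molecule unchanged. No supporting measurement is available to explain the shift.

Going by these compounds, it remains open how an unsubstituted phenyl would compare at this position. The same is true of a phenyl carrying an amine or a carboxylic acid.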